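The source may hold more compounds than are shown below. What is called first, only, known or untested is meant among the compounds shown, and "the series" means these compounds.

In an ADME assay on HepG2 2.2.15 cells (Homo sapiens) for cytotoxicity (on this read-out higher numbers stand for lower toxicity in this test and lower numbers for higher toxicity in this test), three esters on a shared core have been measured. Compound 1 `CC(=O)OCCc1c(-c2ccccc2Cl)c2cc(Cl)ccc2[nH]c1=O` gives 27000 nM, compound 2 `O=C(OCCc1c(-c2ccccc2Cl)c2cc(Cl)ccc2[nH]c1=O)C1CCCCC1` gives 38000 nM, and compound 3 `O=C(OCCc1c(-c2ccccc2Cl)c2cc(Cl)ccc2[nH]c1=O)c1cccnc1` gives 170000 nM, the highest of the three. Compound 4 `O=C(COc1ccccc1)OCCc1c(-c2ccccc2Cl)c2cc(Cl)ccc2[nH]c1=O` changes one group: phenoxymethyl in place of pyridin-3-yl on a carbonyl carbon. For the measured compounds named here, three measured steps bear on this. Swapping methyl for cyclohexyl gives a 1.4-fold higher number from compound 1 to compound 2 (0.15 log units; within the scatter), while pyridin-3-yl gives a 6.3-fold higher number from compound 1 to compound 3 (0.80 log units; beyond the scatter) and a 4.5-fold higher number from compound 2 to compound 3 (0.65 log units; beyond the scatter). No phenoxymethyl ester has been measured, so the guide is that both compounds lacking pyridin-3-yl sit lower. A modest fall is therefore expected, with an estimated step of a 3.1-fold lower number from compound 3 to compound 4 (0.49 log units; beyond the scatter). For compound 4, the estimated value is 55000 nM, with an expected range of 22000 nM to 140000 nM.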

Compound 4, half-maximal cytotoxic concentration: 81000 nM
For compound 4 the middle estimate is 1.5-fold (0.17 log units) below the measured one; measured number inside the range.
By their numbers in this assay, from the lowest: compounds 1 and 2 (each within the scatter of the next); then compound 4; then compound 3.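

In this assay the pyridin-3-yl ester is no longer the only one that stands clear of the methyl and cyclohexyl esters, since phenoxymethyl gives a 3.0-fold higher number from compound 1 to compound 4 (0.48 log units; beyond the scatter) and a 2.1-fold higher number from compound 2 to compound 4 (0.33 log units; beyond the scatter) as well. Its ring of carbon only still falls short of pyridin-3-yl, with a 2.1-fold lower number from compound 3 to compound 4 (0.32 log units; beyond the scatter) on this change. So among these esters, a ring nitrogen is not needed for a clear rise over methyl and cyclohexyl. Nothing available explains this order. A plain phenyl ester or a pyridin-3-yloxymethyl ester would show how much of the gap belongs to the ring nitrogen and how much to the added oxymethyl link.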